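Carbamate to cyclohexylurea on the shared core

The compounds below may be only part of what the source reports. "The series", "measured", "known", "first", "only" and "open" are said of these compounds alone.

Measured so far in a functional assay on NCI-H460 cells (Homo sapiens) for cytotoxicity, read by MTT assay; on this read-out higher numbers stand for weaker inhibition and lower numbers for stronger inhibition:
compound 1 `CCc1cc(S(=O)(=O)N2C[C@H](c3ccccc3)NC2=O)ccc1NC(=O)OC`, 300 nM
compound 2 `CCc1cc(S(=O)(=O)N2C[C@H](c3ccccc3)NC2=O)ccc1NC(=O)OC(C)C`, 60 nM
compound 3 `Cc1cc(S(=O)(=O)N2C(=O)N[C@@H](c3ccccc3)C2C)ccc1NC(=O)c1ccc(N)cc1`, which reaches only the assay limit, > 10000 nM

Among the compounds with values here, compound 2 stands lowest of the two numbers given, with compound 1 next; the one remaining value of compound 3 is a limit of > 10000 nM in this assay, at which 1 of the 3 values shown sits, and not a number. Within the data shown here, the single measured step, a 5.0-fold lower number from compound 1 to compound 2 (0.70 log units; beyond the scatter), shows that enlarging the group on the oxygen of the carbamate carbonyl helped, beyond the scatter.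

Compound 4 `CCc1cc(S(=O)(=O)N2C[C@H](c3ccccc3)NC2=O)ccc1NC(=O)NC1CCCCC1` carries the next change: cyclohexylamino in place of isopropoxy on a carbonyl carbon. Among the measured compounds shown here, this reaches further than the step from compound 1 to compound 2 both in size and in kind, since the oxygen of the carbamate is replaced by a nitrogen bearing a hydrogen and the ring enters where a chain stood; no measured pair tests such a swap. The enlargement itself pointed down in the step from compound 1 to compound 2, so a step of similar or smaller size, a 1.3-fold lower number from compound 2 to compound 4 (0.12 log units; within the scatter), is expected, with wide uncertainty. Compound 4 is therefore estimated at 45 nM, in the range 10 nM to 250 nM.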

Compound 4, half-maximal inhibitory concentration: 300 nM
Compound 4: middle estimate off by 6.7-fold (0.82 log units), on the low side; measured number above the stated range.
By their numbers in this assay, from the lowest: compound 2; then compounds 1 and 4 (each within the scatter of the next). At a limit, above all of these: compound 3.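

In this assay, the gain seen on enlarging the group on this carbonyl carbon does not carry over to cyclohexylamino, which gives a 5.0-fold higher number from compound 2 to compound 4 (0.70 log units; beyond the scatter). Measured against the smaller methoxy, the same group gives no change at the digits printed from compound 1 to compound 4 (within the scatter), so the number of heavy atoms alone does not order these three compounds, and compound 4 goes against the direction of the step from compound 1 to compound 2. Nothing measured among the data shown bears on this result.

The compounds shown leave open whether the reversal follows the nitrogen bearing a hydrogen or the six-membered ring, as the two enter together. Isopropylamino and cyclohexyloxy on the same carbonyl carbon would each carry only one of these two features.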